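Carbamoyl for Fluorophenyl on Two Ring Cores

The source may report more compounds than this note shows. Statements on the series, on what has been measured and on what is new or still open speak of the compounds shown alone.

Measured compounds:
compound 1, `Cc1cc(C)cc(S(=O)(=O)c2c(C(=O)N[C@H]3CCN(Cc4ccccc4F)C3)[nH]c3ccc(Cl)cc23)c1`: in an ADME assay on MT4 cells (Homo sapiens) for cytotoxicity, read by MTT assay, with a stated time of 5 days (a higher number here means that more compound is tolerated, a lower number that less compound is tolerated), compound 1 gives 215000 nM
compound 2, `Cc1cc(C)cc(S(=O)(=O)c2c(C(=O)N[C@H]3CCN(CC(N)=O)C3)[nH]c3ccc(Cl)cc23)c1`: compound 2 gives 28100 nM
compound 3, `Cc1cc(C)cc(S(=O)(=O)c2c(C(=O)NC3CN(Cc4ccccc4F)C3)[nH]c3ccc(Cl)cc23)c1`: compound 3 gives > 238000 nM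

Compound 1 and compound 2 share one core and differ in a single change, (carbamoyl in place of 2-fluorophenyl on a saturated chain carbon bound to an amine nitrogen in a ring). That change produced a 7.7-fold lower number from compound 1 to compound 2 (0.88 log units; beyond the scatter). The result for compound 3 in this assay is a limit of the assay, not a number, sitting at the limit of > 238000 nM in this assay, at which 1 of the 3 values shown sits. The cores of compound 1 and compound 3 differ, but that difference is not broken down here. Compound 4, `Cc1cc(C)cc(S(=O)(=O)c2c(C(=O)NC3CN(CC(N)=O)C3)[nH]c3ccc(Cl)cc23)c1`, is not yet measured; it differs from compound 3 by carbamoyl in place of 2-fluorophenyl on a saturated chain carbon bound to an amine nitrogen in a ring, the same change as between compound 1 and compound 2. For compound 4 a step of about an at least 5.2-fold lower number from compound 3 to compound 4 (0.72 log units; beyond the scatter) is expected in this assay, resting on a 7.7-fold lower number from compound 1 to compound 2 (0.88 log units; beyond the scatter). The starting point of that step is itself only a limit, so the expected range is wide. Compound 4 is estimated at 45000 nM, between 15000 nM and 240000 nM.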

Compound 4, half-maximal cytotoxic concentration: 25500 nM
Beside the measured number, compound 4's estimate is 1.8-fold (0.25 log units) above it, and the stated range covers the measured number.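

In this assay, carbamoyl in place of 2-fluorophenyl on the core of compound 3 gives an at least 9.3-fold lower number from compound 3 to compound 4 (0.97 log units; beyond the scatter), so the change points the same way on both cores: the same change on two cores in this assay, a 7.7-fold lower number (0.88 log units; beyond the scatter) from compound 1 to compound 2 and an at least 9.3-fold lower number (0.97 log units; beyond the scatter) from compound 3 to compound 4; the limit leaves it open whether they differ

Compound 3 gives > 238000 nM, which is a limit of the assay and not a number. From the compounds shown here alone, the size of the step on this core therefore stays unknown, and the data do not show that the change carries over with equal size, while the two carbamoyl compounds cannot be told apart, with a 1.1-fold lower number from compound 2 to compound 4 (0.04 log units; within the scatter).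

Open, going by these compounds, is how a carboxylic acid or an amine would behave in place of carbamoyl on either core. On these data alone, a longer chain between the ring nitrogen and carbamoyl is equally open.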